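The source may hold more compounds than are shown below. What is called first, only, known or untested is meant among the compounds shown, and "the series" means these compounds.

Working notes on the adenosine series.

Three compounds of the shared core have numbers in an assay on isolated protein for inhibition of adenosine deaminase (Bos taurus), with a stated time of 5 min; on this read-out higher numbers stand for weaker inhibition and lower numbers for stronger inhibition. Compound 1 `C[C@H](O)[C@@H](CCc1cccc(-c2cnccn2)c1)n1cnc2c(N)ncnc21` gives 1.9 nM. Compound 2 `C[C@H](O)[C@@H](CCc1cccc(C(N)=O)c1)n1cnc2c(N)ncnc21` gives 2.9 nM. Compound 3 `C[C@H](O)[C@@H](CCc1cccc(C(=O)N(C)C)c1)n1cnc2c(N)ncnc21` gives 1.8 nM. Compound 3 has the lowest of the three numbers, though every gap to it is small: a 1.1-fold lower number from compound 1 to compound 3 (0.02 log units; within the scatter) and a 1.6-fold lower number from compound 2 to compound 3 (0.21 log units; within the scatter), so nothing separates the three.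

Compound 4 `C[C@H](O)[C@@H](CCc1cccc(C(=O)N2CCCC2)c1)n1cnc2c(N)ncnc21` is not yet measured. The change from compound 3 is pyrrolidin-1-yl in place of dimethylamino on a carbonyl carbon. For the measured compounds named here, the one measured step at the same place is a 1.6-fold lower number from compound 2 to compound 3 (0.21 log units; within the scatter), a change of the amide substitution that stayed within the scatter; the replacements on the aromatic carbon, a 1.5-fold higher number from compound 1 to compound 2 (0.18 log units; within the scatter) and a 1.1-fold lower number from compound 1 to compound 3 (0.02 log units; within the scatter), also stayed within it. Nothing measured here points to a shift for a larger group on the carbonyl nitrogen, so no step beyond the scatter is expected in this assay in either direction; the expected step is a 1.1-fold higher number from compound 3 to compound 4 (0.05 log units; within the scatter). Compound 4 is therefore estimated at 2 nM, with a range from 0.9 nM to 4.5 nM.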

Compound 4, inhibition constant: 2.2 nM
Compound 4: middle estimate off by 1.1-fold (0.04 log units), on the low side, within the range that was stated.
By their numbers in this assay, from the lowest: compounds 3, 1, 4 and 2 (each within the scatter of the next).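

With a ring now on the carbonyl nitrogen, this assay still shows no separation: pyrrolidin-1-yl in place of dimethylamino gives a 1.2-fold higher number from compound 3 to compound 4 (0.09 log units; within the scatter). The ring amide also stays within the scatter of the unsubstituted amide, with a 1.3-fold lower number from compound 2 to compound 4 (0.12 log units; within the scatter), and of the pyrazin-2-yl group, with a 1.2-fold higher number from compound 1 to compound 4 (0.06 log units; within the scatter), so the four groups at this place cannot be told apart in this read-out. No supporting data bear on this result.

What would move the number at this place remains open, since every step among the compounds shown lies within the scatter. A carboxylic acid in place of the amide, or a longer chain on the amide nitrogen, would test whether this place responds at all.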